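The source may hold more compounds than are shown below. What is called first, only, known or untested is meant among the compounds shown, and "the series" means these compounds.

Measured so far:
- compound 1 `Cn1c(COc2cccc(C(=O)O)c2)nc2ccc(Oc3ccc(Cl)c(F)c3)nc21`: 1.7 ug/mL in a physicochemical assay for solubility, read by HPLC, measured as thermodynamic solubility, with a stated time of 4 h, at pH 6.8; a higher number here means a more soluble compound, a lower number a less soluble compound
- compound 2 `Cc1ccc(Oc2ccc3nc(COc4cccc(C(=O)O)c4)n(C)c3n2)cc1F`: 5.2 ug/mL in this assay
- compound 3 `Cn1c(COc2cccc(C(=O)O)c2)nc2cnc(Oc3ccc(Cl)c(F)c3)cc21`: 11 ug/mL in this assay

Compound 3 gives the highest of the three numbers, with compound 2 nearest and compound 1 furthest. Compound 4 `Cn1c(COc2cccc(C(=O)O)c2)nc2cnc(Oc3ccc4c(c3)OCC4)cc21` differs from compound 3 by a group of 9 heavy atoms (8 carbon, 1 oxygen; one five-membered non-aromatic ring with 1 hetero atom, one six-membered aromatic ring of carbon only) in place of a group of 8 heavy atoms (6 carbon, 1 fluorine, 1 chlorine; one six-membered aromatic ring of carbon only), on an oxygen on an aromatic ring. Going by the values given here, no measured step covers this exchange; the only step in hand, a 3.1-fold higher number from compound 1 to compound 2 (0.49 log units; beyond the scatter), swaps one small group for another on the same ring and is the nearest guide. On that basis a step of comparable size in this assay, in either direction or none beyond the scatter, is expected for compound 4, written as a 1.4-fold higher number from compound 3 to compound 4 (0.13 log units; within the scatter). The estimate for compound 4 is 15 ug/mL, with a range from 5 ug/mL to 45 ug/mL.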

Compound 4, solubility: 79 ug/mL
The estimate for compound 4 lay 5.3-fold (0.72 log units) below the measured number; measured number above the stated range.
By their numbers in this assay, from the lowest: compound 1; then compound 2; then compound 3; then compound 4.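

On the oxygen on an aromatic ring, replacing 4-chloro-3-fluorophenyl with the group carrying the five-membered non-aromatic ring gives a 7.2-fold higher number from compound 3 to compound 4 (0.86 log units; beyond the scatter) in this assay. The read-out at this position therefore responds to an exchange of the whole aryl group, whereas the earlier step, a 3.1-fold higher number from compound 1 to compound 2 (0.49 log units; beyond the scatter), covered only a small group on that ring. Nothing at hand accounts for the size of this step.

The compounds shown do not separate the effect of the entering ring oxygen from that of losing the chloro and fluoro groups. From the compounds shown here alone, how an amine or a nitrile on the same aromatic ring would read in this assay remains open.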